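The source may hold more compounds than are shown below. What is called first, only, known or untested is meant among the compounds shown, and "the series" means these compounds.

Three nucleoside-like compounds have been measured in a functional assay on EL4 cells (Mus musculus) for inhibition, tested at 100 uM; a higher number here means more inhibition at the concentration tested (going by the name of the read-out), a lower number less inhibition. Compound 1, `OC[C@H]1OC(n2cnc3c(Nc4ccccc4)nccc32)[C@H](O)[C@@H]1O`, gives 10% there. Compound 3, `C[C@H]1OC(n2cnc3c(N)nccc32)[C@H](O)[C@@H]1O`, gives 32% in this assay. Compound 2, `CN(C)c1nccc2c1ncn2[C@H]1C[C@H](O)[C@@H](CO)O1`, reaches only a limit of the assay in this assay, < 5%, and no number is known for it; (the limit of < 5% in this assay, at which 1 of the 3 values shown sits). Going by the values given here, of the two numbers known, compound 1 is the lower one, and compound 3 stands higher by a gap that lies beyond the usual scatter of repeated measurements.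

Compound 4, `CCCCCCNc1nccc2c1ncn2C1O[C@H](CO)[C@@H](O)[C@H]1O`, has not yet been measured in this assay. It differs from compound 1 in one place: hexyl in place of phenyl on a nitrogen on an aromatic ring. Among the compounds with values here, no two measured compounds differ in just this way, so nothing measured tells how large a step this change brings in this assay. The step is therefore expected to be small, a number 2 percentage points higher from compound 1 to compound 4 (within the scatter), with no move beyond the scatter in either direction. Compound 4 is estimated to give 12% in this assay, in a range from 3% to 28%.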

Compound 4, a percentage reported as inhibition, at one concentration (the size of the read-out at that concentration, not a potency): 14%
Estimate against measurement, compound 4: 2 percentage points below, and the stated range covers the measured number.
By their numbers in this assay, from the lowest: compounds 1 and 4 (each within the scatter of the next); then compound 3. At a limit, below all of these: compound 2.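

In this assay, the step for hexyl in place of phenyl on a nitrogen on an aromatic ring is a number 4 percentage points higher from compound 1 to compound 4 (within the scatter). Going by these compounds alone, this is the first step read at this place, and it shows that a six-membered aromatic ring of carbon can give way to an open chain of six carbons with no move beyond the scatter, at least on the core of compound 1. Nothing shown explains why the two groups read alike.

Going by these compounds, whether a shorter chain such as butyl, or a hexyl chain ending in an amine or a carboxylic acid, would bring a larger step in this assay remains open. Also open, on these data alone, is whether a benzyl group on the same nitrogen would read like phenyl or hexyl.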